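Replacing 4-bromophenyl with pentyl in compound 3

The compounds below may be only part of what the source reports. "The series", "measured", "known", "first", "only" and "open" are said of these compounds alone.

Measured in a functional assay on HepG2 cells (Homo sapiens) for antiproliferative activity, read by MTT assay; a higher number here means a weaker inhibitor, a lower number a stronger inhibitor:
Compound 1 (`CC1(C)CCc2cc(C(=O)/C=C/c3ccc(OCc4cn(-c5ccc(Cl)cc5)nn4)cc3)c(O)cc2O1`): "not active" (no number reported)
Compound 2 (`Cc1ccc(-n2cc(COc3ccc(/C=C/C(=O)c4cc5c(cc4O)OC(C)(C)CC5)cc3)nn2)cc1Br`): 117000 nM
Compound 3 (`CC1(C)CCc2c(ccc(C(=O)/C=C/c3ccc(OCc4cn(-c5ccc(Br)cc5)nn4)cc3)c2O)O1`): 136000 nM

Compound 3 stands at 136000 nM in this assay within the usual scatter of compound 2 (117000 nM), and compound 1 gave no number. Compound 4 (`CCCCCn1cc(COc2ccc(/C=C/C(=O)c3ccc4c(c3O)CCC(C)(C)O4)cc2)nn1`) keeps the core of compound 3 and carries pentyl in place of 4-bromophenyl on an aromatic nitrogen. For the measured compounds named here, no step between measured compounds shows what such a swap does. Only a small downward step is expected in this assay and none beyond the scatter. The expected move is a 1.4-fold lower number from compound 3 to compound 4 (0.13 log units; within the scatter) in this estimate. For compound 4 the estimated value is 100000 nM (expected range 35000 nM to 250000 nM).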

Compound 4, half-maximal inhibitory concentration: 9820 nM
For compound 4 the middle estimate is 10-fold (1.01 log units) above the measured one; measured number outside the range, below it.
By their numbers in this assay, from the lowest: compound 4; then compounds 2 and 3 (each within the scatter of the next).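

In this assay, for the compounds shown here, the group on the aromatic nitrogen proves to be a strong lever: pentyl in place of 4-bromophenyl gives a 14-fold lower number from compound 3 to compound 4 (1.14 log units; beyond the scatter), the first step at this position. A chain with no ring therefore serves better here than 4-bromophenyl, and the six-membered aromatic ring is not needed for activity in this assay. Nothing measured explains the size of this step. Going by these compounds, whether a longer chain, a shorter propyl chain or a terminal amine would lower the number further remains open. So does whether pentyl acts likewise on the core of compound 2.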